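Swapping Two Chlorines for Two Methoxy Groups

This account rests on a few compounds, and the source may have more. Where it says the series, first, only, none or still open, it means among the compounds named here.

Going by the values given here, in a functional assay on NCI-H522 cells (Homo sapiens) for inhibition, read by sulforhodamine B assay, with a stated time of 48 h (a higher number here means a weaker inhibitor of growth, a lower number a stronger inhibitor of growth), compound 2 `Nc1cc(N)c2nc(-c3ccccc3)c(NCc3ccc(Cl)c(Cl)c3)nc2c1` gives 2040 nM, the lower of the two numbers measured so far. Compound 1 `CCOC(=O)[C@H](CCC(=O)O)NC(=O)c1ccc(CNc2nc3cc(N)cc(N)c3nc2-c2ccccc2)cc1`, which carries a long ester-bearing tail on the shared core, gives 26900 nM in this assay, and the gap between the two lies well beyond the usual scatter, so compound 2 is the stronger growth inhibitor of the pair.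

Compound 3 `COc1ccc(CNc2nc3cc(N)cc(N)c3nc2-c2ccccc2)cc1OC` has not yet been measured. It differs from compound 2 in a single place: 3,4-dimethoxyphenyl in place of 3,4-dichlorophenyl on a saturated chain carbon bound to a nitrogen on an aromatic ring. The ring at that place keeps its size and shape, but its two chlorine atoms are replaced by two methoxy groups.

Among the compounds with values here, no measured pair shows this exact change, so its size in this assay cannot be read from the data. A swap of this kind is expected to nudge the number upward, toward weaker growth inhibition, and the expected step is a 2.5-fold higher number from compound 2 to compound 3 (0.39 log units; beyond the scatter), a modest loss that may or may not exceed the scatter. Compound 3 is therefore estimated at 5000 nM, with a likely range from 1500 nM to 20000 nM.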

Compound 3, concentration for 50% growth inhibition: 2690 nM
Compound 3: middle estimate off by 1.9-fold (0.27 log units), on the high side; the measured number falls inside the stated range.
By their numbers in this assay, from the lowest: compounds 2 and 3 (each within the scatter of the next); then compound 1.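

In this assay putting 3,4-dimethoxyphenyl in place of 3,4-dichlorophenyl gives a 1.3-fold higher number from compound 2 to compound 3 (0.12 log units; within the scatter) and so, on a saturated chain carbon bound to a nitrogen on an aromatic ring, these two groups cannot be told apart by this read-out. Going by these compounds alone, the entering group has 10 heavy atoms against 8 and 2 hydrogen-bond acceptors against 0, and this place accepts both differences in this one pair without a gap beyond the scatter, something the earlier compounds could not show. No measurement shown here gives a reason for this result.

As far as these compounds go, both of these rings carry a pair of groups, so it remains open what a bare phenyl ring, a single chlorine, or a group of a different kind such as an amine or a carboxylic acid would give at this place. From the compounds shown here alone, it is also open whether the same swap would give so small a step if the phenyl on the shared core were replaced by a methyl group.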